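A Methoxymethyl Group on the Core of Compound 2

The source may hold more compounds than are shown below. What is called first, only, known or untested is meant among the compounds shown, and "the series" means these compounds.

Two closely related compounds have been tested in a functional assay on MIA PaCa-2 cells (Homo sapiens) for antiproliferative activity, read by MTT assay, with a stated time of 72 h; a lower number here means a stronger inhibitor, a higher number a weaker inhibitor. Compound 1 `COc1cc(CC(O)(COCc2ccccc2)COCc2ccccc2)nc(OC)n1` carries a six-membered aromatic ring with 2 hetero atoms on its central chain. In this assay compound 1 gives > 100000 nM, which is a limit of the assay rather than a number. Compound 2 `O=c1cc(CC(O)(COCc2ccccc2)COCc2ccccc2)[nH]c(=O)[nH]1` carries a smaller group of 8 heavy atoms in place of that ring. In this assay compound 2 gives > 100000 nM, again a limit. The step that the two limits leave unreadable from compound 1 to compound 2 therefore cannot be read, and all that the measured data show is the limit of > 100000 nM in this assay, at which 2 of the 2 values shown sit.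

Compound 3 `COCn1c(CC(O)(COCc2ccccc2)COCc2ccccc2)cc(=O)[nH]c1=O` differs from compound 2 by methoxymethyl in place of hydrogen on an aromatic nitrogen. Going by the values given here, no measured step bears on this change, and both measured compounds sit at the limit, so there is no step size to carry over. The expectation is that compound 3 stays where the measured compounds stand, with the step of a number no higher from compound 2 to compound 3 (the limit leaves the size open) expected to be none beyond the scatter. Compound 3 is therefore estimated at 100000 nM, within 30000 nM to 300000 nM, and is most likely to be reported only as a limit.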

Compound 3, half-maximal inhibitory concentration: > 100000 nM
Compound 3 was reported as a limit; the forecaster's own chance of this, stated with the estimate: 85%; the middle value sits exactly at the limit.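

Compound 2 and compound 3 are both reported only as limits in this assay, and the step between them cannot be read. The compounds shown leave open how far each one lies from the limit, and whether methoxymethyl in place of hydrogen on the aromatic nitrogen changes the activity at all.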